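The source may hold more compounds than are shown below. What is called first, only, known or untested is meant among the compounds shown, and "the series" means these compounds.

Compound 1, `O=c1c2c(Nc3ccccc3)nn(-c3ccccc3)c2nc(Nc2ccccc2)n1-c1ccccc1`, is the reference point of this account. In a functional assay on the whole organism (strain Wistar albino) for inhibition, with Rattus norvegicus as the target, read by paw edema, with a stated time of 1 h, at a dose of 25 mg/kg by the oral route (a higher number here means more inhibition at the dose given (going by the name of the read-out), a lower number less inhibition), compound 1 gives 48.1%, the second highest of the three numbers at hand. Compound 2, `O=c1c2c(Nc3ccccc3)nn(-c3ccc([N+](=O)[O-])cc3)c2nc(Nc2ccccc2)n1-c1ccccc1`, gives 43.9% in this assay, and the step is a number 4.2 percentage points lower from compound 1 to compound 2 (within the scatter). Compound 3, `NS(=O)(=O)c1ccc(-n2nc(Nc3ccccc3)c3c(=O)n(-c4ccccc4)c(Nc4ccccc4)nc32)cc1`, gives 60.2% in this assay; here the step is a number 12.1 percentage points higher from compound 1 to compound 3 (beyond the scatter), and from compound 2 the step is a number 16.3 percentage points higher from compound 2 to compound 3 (beyond the scatter).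

Compound 4, `Cc1ccc(Nc2nn(-c3ccccc3)c3nc(Nc4ccccc4)n(-c4ccccc4)c(=O)c23)cc1`, differs from compound 1 in one place: methyl in place of hydrogen on an aromatic carbon. Among the compounds with values here, none of the measured steps makes this same change, and none of them sits on the same ring; the two changes that were measured, nitro and sulfamoyl, gave one step within the scatter and one modest step upward. Within the data shown here, with no step of the methyl kind to lean on, compound 4 is expected to stay close to compound 1, so the step of a number 0.1 percentage points lower from compound 1 to compound 4 (within the scatter) is estimated to lie within the scatter. For compound 4 the expected value in this assay is 48%, with a range from 38% to 58%.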

Compound 4, a percentage reported as inhibition, in the whole organism at one dose (the size of the read-out at that dose, not a potency): 55.7%
Beside the measured number, compound 4's estimate is 7.7 percentage points below it, and the stated range covers the measured number.
By their numbers in this assay, from the lowest: compounds 2, 1, 4 and 3 (each within the scatter of the next, the first and the last beyond it).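

In this assay, replacing hydrogen with methyl at this position gives a number 7.6 percentage points higher from compound 1 to compound 4 (within the scatter), so this change, which turns anilino into (4-methylphenyl)amino, leaves the read-out within the usual scatter. It is the only step shown on an anilino ring, on an aromatic carbon para to a large group, and the nitro and sulfamoyl steps sit on a different ring, so they cannot be set directly against it. Nothing at hand explains the result.

As far as these compounds go, it remains open whether a chlorine, a methoxy group, an amine, a carboxylic acid or a longer chain such as propyl at the same position would also stay within the scatter. From the compounds shown here alone, it is equally open how methyl would read on the other aromatic rings of the shared core, or combined with sulfamoyl in one compound.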